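A few compounds are considered here, and "the series" means these few. Any claim that something is new, unique, unknown or untested is made for them only; others in the source may bear on it.

Compound 1, `COc1c(F)ccc(F)c1C1CCN(c2ccn3c(CC4CC4)nnc3c2Cl)CC1`: in an ADME assay on a cell-free system (plasma, Rattus norvegicus) for protein binding (a lower number here means a smaller unbound share, a higher number a larger unbound share of the compound), compound 1 gives < 0.01, which is a limit of the assay.
Compound 2, `COc1c(F)cccc1C1CCN(c2ccn3c(CC4CC4)nnc3c2C(F)(F)F)CC1`: in this assay compound 2 gives < 0.01, also a limit of the assay.

Compound 2 thus stands at the limit of < 0.01 in this assay, at which 2 of the 2 values shown sit, so only a bound and no number is known for it. Compound 3, `COc1c(F)ccc(F)c1C1CCN(c2ccn3c(CC4CC4)nnc3c2C(F)(F)F)CC1`, differs from compound 2 by fluoro in place of hydrogen on an aromatic carbon. Among the measured compounds shown here, no step between measured compounds is available. In this assay no change beyond the scatter is expected, and the step is estimated as a step that the limit leaves unreadable from compound 2 to compound 3. Compound 3 is expected to give 0.005, within 0.002 to 0.012, most likely again reported only as a limit.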

Compound 3, unbound fraction: < 0.01
Compound 3 was reported as a limit; the forecaster's own chance of this, stated with the estimate: 85%; the middle value is on the limit's open side.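

Neither the step from compound 2 to compound 3 nor the step from compound 1 to compound 3 can be read in this assay: the limit of < 0.01 in this assay, at which 3 of the 3 values shown sit. The compounds shown leave open how large the unbound fraction of each actually is.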